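This account rests on a few compounds, and the source may have more. Where it says the series, first, only, none or still open, it means among the compounds named here.

Measured so far in a functional assay on the whole organism (Hindlimb) for inhibition, with Mus musculus as the target, with a stated time of 4 h; on this read-out higher numbers stand for an effect only at larger amounts of compound and lower numbers for an effect already at smaller amounts:
compound 1 `CC1(C)CC12NC(=O)N(NC(=O)c1ccc(Cl)cc1)C2=O`: 300 mg/kg
compound 2 `CC1(C)CC12NC(=O)N(NC(=O)c1ccc(Br)cc1)C2=O`: 300 mg/kg
compound 3 `CC1(C)CC12NC(=O)N(NC(=O)c1ccc(C(F)(F)F)cc1)C2=O`: 30 mg/kg

Compound 3 gives the lowest number of the three: the steps are a 10-fold lower number from compound 1 to compound 3 (1.00 log units; beyond the scatter) and a 10-fold lower number from compound 2 to compound 3 (1.00 log units; beyond the scatter), while the two halogen analogues lie within the scatter of each other, no change at the digits printed from compound 1 to compound 2 (within the scatter). Compound 4 `CC1(C)CC12NC(=O)N(NC(=O)c1ccc([N+](=O)[O-])cc1)C2=O` alters only the substituent on the aromatic carbon: nitro in place of trifluoromethyl on an aromatic carbon. Among the compounds with values here, no measured step bears directly on this exchange; the two steps known at this position both put trifluoromethyl in place of a halogen and both lower the number. Whether nitro follows trifluoromethyl or the halogens cannot be read from three numbers, so a step of a 3.3-fold higher number from compound 3 to compound 4 (0.52 log units; beyond the scatter) is expected, with wide uncertainty. Compound 4 is expected to give 100 mg/kg, within a range of 30 mg/kg to 300 mg/kg.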

Compound 4, minimum effective dose: 300 mg/kg
The estimate for compound 4 lay 3.0-fold (0.48 log units) below the measured number, within the range that was stated.
By their numbers in this assay, from the lowest: compound 3; then compounds 1, 2 and 4 (each within the scatter of the next).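

Nitro does not keep the lower number seen with trifluoromethyl on this aromatic carbon (a 10-fold higher number from compound 3 to compound 4 (1.00 log units; beyond the scatter)). It instead matches both halogen analogues (no change at the digits printed from compound 2 to compound 4 (within the scatter); no change at the digits printed from compound 1 to compound 4 (within the scatter)), so among these four groups only trifluoromethyl stands apart. No measured evidence accounts for this separation.

Still open, as far as these compounds go, is whether the lower number is unique to trifluoromethyl or is shared by other groups at this position, such as a nitrile, an amine or a carboxylic acid.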